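The source may report more compounds than this note shows. Statements on the series, on what has been measured and on what is new or still open speak of the compounds shown alone.

Measured so far in an ADME assay on Vero cells (Chlorocebus sabaeus) for cytotoxicity, read by MTT assay, with a stated time of 96 h; on this read-out lower numbers stand for higher toxicity in this test and higher numbers for lower toxicity in this test:
Compound 1 `COc1cc(/N=C/c2cccs2)ccc1-c1cnco1` gives 406000 nM
Compound 2 `COc1cc(NCc2scnc2C)ccc1-c1cnco1` gives 73700 nM

Of these two numbers, the lower belongs to compound 2 at 73700 nM and the higher to compound 1 at 406000 nM with a gap beyond the usual scatter. Compound 2 is thus the more toxic of the pair in this assay on this evidence.

Compound 3 `COc1cc(NCc2ccc(Br)s2)ccc1-c1cnco1` has not yet been measured. It keeps the shared core of compound 2 and differs in one place, as 5-bromothiophen-2-yl in place of 4-methyl-1,3-thiazol-5-yl on a saturated chain carbon bound to a nitrogen on an aromatic ring shows, with 5-bromothiophen-2-yl in place of 4-methyl-1,3-thiazol-5-yl on a saturated chain carbon bound to a nitrogen on an aromatic ring.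

Among the compounds with values here, no measured pair shows this exchange, so the data give no direct guide to its size. The reading therefore starts from compound 2 at 73700 nM as the closest measured structure. The expected change is a 1.5-fold lower number from compound 2 to compound 3 (0.17 log units; within the scatter) and is estimated as small, toward a lower number and within the scatter. The estimate for compound 3 is 50000 nM with 15000 nM to 160000 nM as its expected range.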

Compound 3, half-maximal cytotoxic concentration: 47300 nM
For compound 3 the middle estimate is 1.1-fold (0.02 log units) above the measured one; measured number inside the range.
By their numbers in this assay, from the lowest: compounds 3 and 2 (each within the scatter of the next); then compound 1.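

Putting 5-bromothiophen-2-yl in place of 4-methyl-1,3-thiazol-5-yl on a saturated chain carbon bound to a nitrogen on an aromatic ring gives, in this assay, a 1.6-fold lower number from compound 2 to compound 3 (0.19 log units; within the scatter) and is the only one-place step among the compounds shown. At this position, then, a five-membered aromatic ring with one hetero atom and a bromine reads the same within the scatter as one with two hetero atoms and a methyl, although the two groups differ in their hetero atoms, their hydrogen-bond acceptor count and their substituent. Nothing available explains why these two groups read alike in this test.

From the compounds shown here alone, the step changes the ring and its substituent together, so it remains open whether either matters alone, which a plain thiophen-2-yl or a 5-chlorothiophen-2-yl at the same place would help to separate. Going by these compounds, it also remains open how this position responds to groups further from these two, such as a phenyl ring, a morpholine or a carboxylic acid, or to a longer chain carrying the same bromothiophene.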